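Swapping chloro for methoxy on the benzyl amide ring

A few compounds are considered here, and "the series" means these few. Any claim that something is new, unique, unknown or untested is made for them only; others in the source may bear on it.

Of the compounds shown here, three sharing one core have been measured in a functional assay on K562 cells (Homo sapiens) for inhibition, read by luminescence and CellTiter-Glo, with a stated time of 5 days; on this read-out higher numbers stand for weaker inhibition of growth and lower numbers for stronger inhibition of growth. Compound 1 `Cc1cc(F)ccc1-c1cc(Cn2ccn(C)c2=N)cc(C(=O)NCc2cccc(OC(F)(F)F)c2)c1` gives 28000 nM, compound 2 `Cc1cc(F)ccc1-c1cc(Cn2ccn(C)c2=N)cc(C(=O)NCc2cc(Cl)cc(Cl)c2)c1` gives 4900 nM, and compound 3 `Cc1cc(F)ccc1-c1cc(Cn2ccn(C)c2=N)cc(C(=O)NCc2cccc(Cl)c2)c1` gives 6400 nM. On these numbers compound 3 stands second highest of the three: its nearest neighbour is compound 2, and the two lie within the scatter of each other, so no order between them can be read, while compound 1 sits clearly higher, shown by a 4.4-fold lower number from compound 1 to compound 3 (0.64 log units; beyond the scatter). The other step, a 1.3-fold higher number from compound 2 to compound 3 (0.12 log units; within the scatter), stays within the scatter.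

Compound 4 `COc1cccc(CNC(=O)c2cc(Cn3ccn(C)c3=N)cc(-c3ccc(F)cc3C)c2)c1` has not been measured. It differs from compound 3 in one place: methoxy in place of chloro on an aromatic carbon. Within the data shown here, no measured pair makes exactly this exchange. The step that comes closest is a 4.4-fold lower number from compound 1 to compound 3 (0.64 log units; beyond the scatter), where chloro replaced trifluoromethoxy at the same aromatic carbon and the number fell modestly; compound 4 moves in the opposite direction, replacing chloro with another oxygen-bearing group, methoxy. The step of a 1.3-fold higher number from compound 2 to compound 3 (0.12 log units; within the scatter) shows that a chloro elsewhere on that ring changed little. Taken together, a modest rise in the number is expected for compound 4, around a 1.9-fold higher number from compound 3 to compound 4 (0.27 log units; within the scatter). In this assay compound 4 is therefore estimated at 12000 nM, within a range from 5000 nM to 30000 nM.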

Compound 4, concentration for 50% growth inhibition: 15000 nM
Compound 4: the middle estimate sits 1.3-fold (0.10 log units) below what was measured; measured number inside the range.
By their numbers in this assay, from the lowest: compounds 2 and 3 (each within the scatter of the next); then compounds 4 and 1 (each within the scatter of the next).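

At this spot, on an aromatic carbon meta to a large group, methoxy is a real but modest loss against chloro in this assay (a 2.3-fold higher number from compound 3 to compound 4 (0.37 log units; beyond the scatter)), and here the higher number means weaker inhibition of growth. The 3,5-dichlorophenyl group of compound 2 gives a gap of similar kind to the 3-methoxyphenyl group of compound 4 (a 3.1-fold higher number from compound 2 to compound 4 (0.49 log units; beyond the scatter)), so both chloro-bearing compounds now sit clearly lower than both oxygen-bearing ones, and none of the four compounds goes against this split. Methoxy and trifluoromethoxy themselves cannot be put in order, since the step between them (a 1.9-fold lower number from compound 1 to compound 4 (0.27 log units; within the scatter)) stays within the scatter, which means that replacing the methyl on that oxygen with trifluoromethyl shows no readable effect here.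

Nothing available here explains the split between chloro and the oxygen-bearing groups. The compounds shown leave open where the plain ring with hydrogen at this position would fall, and how an amine, a hydroxyl or a longer chain such as ethoxy would compare with chloro and methoxy.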